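Butylamino in place of the chlorophenyl on the shared core

A few compounds are considered here, and "the series" means these few. Any claim that something is new, unique, unknown or untested is made for them only; others in the source may bear on it.

The series shares one core carrying a biphenyl ether arm, and the compounds differ in the group on the other side of that core. In a functional assay on the whole organism (strain Wistar) for inhibition, with Rattus norvegicus as the target, read by paw edema, with a stated time of 4 h, at a dose of 10 mg/kg by the oral route (a lower number here means less inhibition, a higher number more inhibition at the dose given (going by the name of the read-out)), compound 1 `Clc1ccc(-c2nnc(COc3ccc(-c4ccccc4)cc3)o2)cc1` gives 77.3%, the highest of the three numbers. Compound 2 `Clc1ccc(COc2nnc(COc3ccc(-c4ccccc4)cc3)o2)c(Cl)c1` gives 29.5% in this assay, and compound 3 `COc1ccc2cc(C(C)c3nnc(COc4ccc(-c5ccccc5)cc4)o3)ccc2c1` gives 25%, both well beyond the scatter below compound 1. The untested compound 4 `CCCCNc1nnc(COc2ccc(-c3ccccc3)cc2)o1` keeps the biphenyl ether arm and the core of compound 1 but changes the other substituent: butylamino in place of 4-chlorophenyl on an aromatic carbon. Within the data shown here, no step between two measured compounds matches this change, so the expectation rests on the observation that compound 1 alone, with the 4-chlorophenyl, stands high while the two compounds bearing other groups at that place stand low. The account therefore expects a sizeable drop, a number 37.3 percentage points lower from compound 1 to compound 4 (beyond the scatter), on moving away from the 4-chlorophenyl. Compound 4 is estimated at 40% in this assay, within a range from 20% to 62%.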

Compound 4, a percentage reported as inhibition, in the whole organism at one dose (the size of the read-out at that dose, not a potency): 15.9%
Estimate against measurement, compound 4: 24.1 percentage points above; measured number below the stated range.
By their numbers in this assay, from the lowest: compounds 4, 3 and 2 (each within the scatter of the next, the first and the last beyond it); then compound 1.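

Among these compounds, the step gives the first direct reading of this position: with the biphenyl ether arm and the shared core unchanged, butylamino in place of 4-chlorophenyl on an aromatic carbon brings a number 61.4 percentage points lower from compound 1 to compound 4 (beyond the scatter) in this assay. The high number of compound 1 is therefore not kept when its aromatic ring of carbon only gives way to an open chain joined through nitrogen, so this place is far from indifferent to the change. Nothing available here explains the size of the step.

Among the compounds shown here, the single step joins several changes at once, so it cannot say whether the loss goes with the missing ring, the missing chlorine or the entering nitrogen. An unsubstituted phenyl, a plain butyl chain or a benzylamino group on the same carbon would begin to separate these.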